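The source may hold more compounds than are shown below. What is called first, only, known or untested is meant among the compounds shown, and "the series" means these compounds.

Working notes on the series. Three compounds have numbers in a functional assay on CHO cells for antagonist activity at prostaglandin E2 receptor EP3 subtype (Homo sapiens), read by cAMP accumulation, with a stated time of 30 min; on this read-out lower numbers stand for stronger inhibition and higher numbers for weaker inhibition. Compound 1 `CC(C)C(CC1C(=O)NC(=O)N1C)c1ccc(-c2ccc3cccc(F)c3c2)[nH]c1=O` gives 65 nM. Compound 2 `CC(C)[C@H](C[C@H]1OC(=O)NC1=O)c1ccc(-c2ccc3cccc(F)c3c2)[nH]c1=O` gives 15 nM. Compound 3 `CCn1ncc2c(F)cc(-c3ccc(C(/C=C4\OC(=O)NC4=O)(CC)CC)c(=O)[nH]3)cc21` gives 33 nM. On these numbers compound 1 stands highest of the three; the nearest number is that of compound 3, and that gap lies within the scatter, while the number of compound 2 lies further off, beyond the scatter.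

Compound 4 `CC(C)C(c1ccc(-c2ccc3cccc(F)c3c2)[nH]c1=O)C1C(=O)NC(=O)N1C` is not yet measured in this assay. Its difference from compound 1 is 3-methyl-2,5-dioxoimidazolidin-4-yl in place of (3-methyl-2,5-dioxoimidazolidin-4-yl)methyl on a saturated chain carbon bound to an aromatic carbon and a saturated chain carbon: the hydantoin ring is joined straight to the chain carbon rather than through one more carbon. Within the data shown here, no measured pair in the set follows this kind of shortening, so no step of this sort is known. The expectation, resting on nothing more than the absence of such a pair, is for a step from compound 1 to compound 4 of a 2.3-fold higher number from compound 1 to compound 4 (0.36 log units; beyond the scatter), towards a weaker number, with the chance that it stays within the scatter. The estimate for compound 4 in this assay is 150 nM, with a range from 40 nM to 600 nM.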

Compound 4, half-maximal inhibitory concentration: 320 nM
Compound 4: the middle estimate sits 2.1-fold (0.33 log units) below what was measured; measured number inside the range.
By their numbers in this assay, from the lowest: compound 2; then compounds 3 and 1 (each within the scatter of the next); then compound 4.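

In this assay, among these compounds, the shortening gives the first measured step at this position: it runs a 4.9-fold higher number from compound 1 to compound 4 (0.69 log units; beyond the scatter) and lies beyond the scatter, towards weaker inhibition. On this saturated chain carbon bound to an aromatic carbon and a saturated chain carbon, 3-methyl-2,5-dioxoimidazolidin-4-yl is therefore not interchangeable with (3-methyl-2,5-dioxoimidazolidin-4-yl)methyl, even though the hydantoin ring itself stays the same. The earlier compounds shown here, among which no two differ in one place, could not show this, and the finding rests on this single pair.

The compounds shown leave open whether a longer chain between this carbon and the hydantoin ring would hold or improve the number of compound 1, and how a carboxylic acid or an amine would fare in place of the ring. Among the compounds shown here, no measurement at hand bears on why removing the one carbon weakens the number.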